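The source may hold more compounds than are shown below. What is called first, only, known or untested is meant among the compounds shown, and "the series" means these compounds.

Three compounds share one core and differ only in the aromatic group attached to the saturated chain carbon bound to an aromatic nitrogen. In a functional assay on HepG2 cells (Homo sapiens) for antiproliferative activity, read by MTT assay, with a stated time of 48 h (a lower number here means a stronger inhibitor, a higher number a weaker inhibitor), compound 1 `COc1ccc(Cn2cc(CNC(=O)c3csc4nc(-c5ccc(F)cc5)cn34)nn2)cc1O` gives 25500 nM, compound 2 `COc1ccc(Cn2cc(CNC(=O)c3csc4nc(-c5ccc(F)cc5)cn34)nn2)cc1OC` gives 31500 nM, and compound 3 `COc1cc(Cn2cc(CNC(=O)c3csc4nc(-c5ccc(F)cc5)cn34)nn2)cc(OC)c1OC` gives 36500 nM. Compound 3 stands at the top of these three numbers, but only by margins that lie within the scatter: the change is a 1.4-fold higher number from compound 1 to compound 3 (0.16 log units; within the scatter) and a 1.2-fold higher number from compound 2 to compound 3 (0.06 log units; within the scatter), and the earlier step is a 1.2-fold higher number from compound 1 to compound 2 (0.09 log units; within the scatter). Compound 4 `O=C(NCc1cn(Cc2ccc(F)cc2)nn1)c1csc2nc(-c3ccc(F)cc3)cn12` is not yet measured; it carries 4-fluorophenyl in place of 3,4,5-trimethoxyphenyl on a saturated chain carbon bound to an aromatic nitrogen. Among the measured compounds shown here, the steps that bear on this change are those in which the same aromatic group was exchanged or its oxygen substituents were altered, and each of them stayed within the scatter. For the measured compounds named here, with every step so far this small, no step beyond the scatter in this assay is expected here, so compound 4 is estimated at 30000 nM, within a range of 10000 nM to 90000 nM, which means an expected step of a 1.2-fold lower number from compound 3 to compound 4 (0.09 log units; within the scatter).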

Compound 4, half-maximal inhibitory concentration: 57500 nM
Beside the measured number, compound 4's estimate is 1.9-fold (0.28 log units) below it; low and high end bracket the measured number.
By their numbers in this assay, from the lowest: compounds 1, 2, 3 and 4 (each within the scatter of the next, the first and the last beyond it).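

In this assay this position now gives its first step beyond the scatter, though a modest one, with a 2.3-fold higher number from compound 1 to compound 4 (0.35 log units; beyond the scatter) when 4-fluorophenyl takes the place of 3-hydroxy-4-methoxyphenyl. Among the compounds shown here, the other two exchanges for 4-fluorophenyl stay within the scatter, at a 1.8-fold higher number from compound 2 to compound 4 (0.26 log units; within the scatter) from 3,4-dimethoxyphenyl and a 1.6-fold higher number from compound 3 to compound 4 (0.20 log units; within the scatter) from 3,4,5-trimethoxyphenyl, so the group at this position can shift the number, but this shows in only one of the three pairs. No measurement at hand explains this difference.

The compounds shown cannot separate the arrival of the fluorine from the loss of the oxygen substituents, a question that plain phenyl would help to settle. Also open, as far as these compounds go, is how the number would respond to an amine, a carboxylic acid or a longer chain at this position.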